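This account rests on a few compounds, and the source may have more. Where it says the series, first, only, none or still open, it means among the compounds named here.

Compound 1, `COCOc1cc(/C=C/C(=O)OCC(=O)NCc2ccco2)ccc1OCc1ccccc1`, was tested in a functional assay on BEL-7404 cells (Homo sapiens) for cytotoxicity, read by MTT assay, with a stated time of 72 h; on this read-out higher numbers stand for weaker inhibition and lower numbers for stronger inhibition. On this read-out compound 1 gives only a limit, > 200000 nM. Compound 2, `CCOc1ccc(COc2c(OC)cc(/C=C/C(=O)OCC(=O)Nc3ccc(Cl)cc3)cc2OC)cc1`, likewise gives only a limit in this assay, > 200000 nM. Compound 3, `CCOc1ccc(COc2c(OC)cc(/C=C/C(=O)OCC(=O)Nc3ccccc3)cc2OC)cc1`, also gives only a limit in this assay, > 200000 nM. For the measured compounds named here, the single measured step, a step that the two limits leave unreadable from compound 2 to compound 3, is unreadable, as both of its values sit at the limit of > 200000 nM in this assay, at which 3 of the 3 values shown sit.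

Compound 4, `COCOc1cc(/C=C/C(=O)OCC(=O)Nc2ccc(Cl)cc2)ccc1OCc1ccccc1`, has not yet been measured. It differs from compound 1 in one place: 4-chlorophenyl in place of (furan-2-yl)methyl on an amide-type nitrogen. Going by the values given here, no measured step covers this exchange on the amide-type nitrogen. What the three values do show is that all three measured compounds, one carrying a (furan-2-yl)methyl group and two carrying phenyl-type groups on that nitrogen, stay at the limit in this assay. Compound 4 is therefore expected to stay near that limit as well, with the step that the limit leaves unreadable from compound 1 to compound 4 estimated to lie within the scatter. The estimate for compound 4 in this assay is 300000 nM, between 100000 nM and 1000000 nM.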

Compound 4, half-maximal inhibitory concentration: > 200000 nM
Compound 4 ended at the assay's limit (the forecaster's own chance of this, stated with the estimate: 85%); the middle value lies beyond the limit too.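

Compound 1 and compound 4 both give only a limit, not a number, so no step between them can be read: the limit of > 200000 nM in this assay, at which 4 of the 4 values shown sit.

The compounds shown leave open whether any group on the amide-type nitrogen gives a measurable value in this assay.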